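Aryl swap on the 2-hydroxyethoxy compound

The source may hold more compounds than are shown below. What is called first, only, known or untested is meant among the compounds shown, and "the series" means these compounds.

Measured in a functional assay on SK-MEL-28 cells (Homo sapiens) for cytotoxicity, read by CCK-8 assay, with a stated time of 24 h; on this read-out lower numbers stand for stronger inhibition and higher numbers for weaker inhibition:
- compound 1 `COc1ccccc1Oc1c(N)nc(-c2ccc(Cl)cc2)nc1Cl`: 120 nM
- compound 2 `COc1ccccc1Oc1c(N)nc(-c2cccc(F)c2)nc1OCCO`: 3210 nM

Compound 2, at 3210 nM, holds the higher of the two numbers, and compound 1, at 120 nM, lies lower by a gap beyond the scatter. For the measured compounds named here, these two compounds differ in more than one place, so no single-change step is available.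

Compound 3 `COc1ccccc1Oc1c(N)nc(-c2ccc(Cl)cc2)nc1OCCO` keeps the 2-hydroxyethoxy group of compound 2 and carries 4-chlorophenyl in place of 3-fluorophenyl on an aromatic carbon.

Compound 3 shares 4-chlorophenyl with compound 1 at 120 nM, so a move toward that number is expected. The estimated change is a downward step beyond the scatter, a 4.0-fold lower number from compound 2 to compound 3 (0.60 log units; beyond the scatter). For compound 3 the expected value is 800 nM, with an estimated range from 200 nM to 3000 nM.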

Compound 3, half-maximal inhibitory concentration: > 80000 nM
Compound 3: a limit, no number; the forecaster's own chance of this, stated with the estimate: 2%; at least 100-fold (2.00 log units) between middle value and limit.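

Compound 3 in this assay gives a limit of the assay and not a number: the limit of > 80000 nM in this assay, at which 1 of the 3 values shown sits.
The aryl group on the carbon between two ring nitrogen atoms is therefore not an interchangeable part in the 2-hydroxyethoxy compounds: 4-chlorophenyl in place of 3-fluorophenyl gives an at least 24-fold higher number from compound 2 to compound 3 (1.39 log units; beyond the scatter) in this pair. 4-Chlorophenyl alone also does not secure a low number, since 2-hydroxyethoxy in place of chloro gives an at least 660-fold higher number from compound 1 to compound 3 (2.82 log units; beyond the scatter) with that aryl group unchanged.

The compounds shown leave open how 3-fluorophenyl would read with chloro in place of 2-hydroxyethoxy, and they give no cause for either step. Also open, on these data alone, is whether a methoxy group, an amine or a longer chain ending in a carboxylic acid at the carbon carrying 2-hydroxyethoxy would read closer to compound 1 or to compound 3.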